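Chloro for Methyl on the Benzyl Group of Compound 3

The compounds below may be only part of what the source reports. "The series", "measured", "known", "first", "only" and "open" are said of these compounds alone.

In a functional assay on HT-29 cells (Homo sapiens) for cytotoxicity, read by MTT assay, with a stated time of 24 h, tested at 32 ug/mL (on this read-out higher numbers stand for a stronger effect at the one concentration tested and lower numbers for a weaker effect), compound 1 `CN1CCN(CC(=O)Nc2ccc(-c3nc(-c4ccccc4)c(-c4ccccc4)n3C)cc2)CC1` gives 49.1%.
In this assay, compound 2 `Cn1c(-c2ccc(NC(=O)CN3CCN(c4ccccc4)CC3)cc2)nc(-c2ccccc2)c1-c1ccccc1` gives 60.5%.
In this assay, compound 3 `Cc1ccc(CN2CCN(CC(=O)Nc3ccc(-c4nc(-c5ccccc5)c(-c5ccccc5)n4C)cc3)CC2)cc1` gives 42.3%.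

Compound 3 holds the lowest of the three numbers, though the gap to compound 1 is small: a number 6.8 percentage points lower from compound 1 to compound 3 (within the scatter). The gap to compound 2 is larger: a number 18.2 percentage points lower from compound 2 to compound 3 (beyond the scatter). Compound 4 `Cn1c(-c2ccc(NC(=O)CN3CCN(Cc4ccc(Cl)cc4)CC3)cc2)nc(-c2ccccc2)c1-c1ccccc1` differs from compound 3 in one place: chloro in place of methyl on an aromatic carbon. Among the compounds with values here, the measured steps all change what sits on the amine nitrogen in the ring (a number 11.4 percentage points higher from compound 1 to compound 2 (beyond the scatter), a number 6.8 percentage points lower from compound 1 to compound 3 (within the scatter), a number 18.2 percentage points lower from compound 2 to compound 3 (beyond the scatter)); none of them exchanges one substituent for another on the aromatic ring of the 4-methylbenzyl group, so no measured step bears directly on this change. With the methyl and chloro groups counted as equal in size and in donors and acceptors, the account expects no step beyond the scatter, that is a number 1.7 percentage points higher from compound 3 to compound 4 (within the scatter). Compound 4 is therefore estimated at 44% in this assay, within a range from 30% to 58%.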

Compound 4, a percentage reported as activity, at one concentration (the size of the read-out at that concentration, not a potency): 55.6%
Compound 4: the middle estimate sits 11.6 percentage points below what was measured, and the stated range covers the measured number.
By their numbers in this assay, from the lowest: compounds 3, 1, 4 and 2 (each within the scatter of the next, the first and the last beyond it).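

In this assay, the substituent on this aromatic carbon matters: the step of a number 13.3 percentage points higher from compound 3 to compound 4 (beyond the scatter) shows that exchanging methyl for chloro, two groups of one heavy atom each with no hydrogen-bond donors or acceptors, can move the number beyond the scatter. With chloro in place, the benzyl-type group no longer stands apart from the other groups on the ring amine nitrogen, as the steps of a number 4.9 percentage points lower from compound 2 to compound 4 (within the scatter) and a number 6.5 percentage points higher from compound 1 to compound 4 (within the scatter) both lie within the scatter. Nothing measured here accounts for the rise.

The compounds shown leave open how an unsubstituted benzyl group, or a bromo or methoxy group on the same ring, would read, so it cannot be said whether chloro raises the number or methyl lowers it. Going by these compounds, whether chloro would give a similar number elsewhere on that ring also remains open.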